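The source may hold more compounds than are shown below. What is called first, only, known or untested is meant among the compounds shown, and "the series" means these compounds.

Measured so far:
compound 1, `O=C(Nc1cccc(-c2oc3cc(-c4ccc(F)cc4)ccc3c(=O)c2O)c1)c1ccc(Br)cc1`, 24900 nM
compound 2, `O=C(Nc1cccc(-c2oc3cc(-c4ccc(F)cc4)ccc3c(=O)c2O)c1)c1cccc(F)c1`, 2510 nM

Both were run in a functional assay on MDA-MB-231 cells (Homo sapiens) for antiproliferative activity, read by CCK-8 assay, with a stated time of 72 h; on this read-out higher numbers stand for weaker inhibition and lower numbers for stronger inhibition. Within the data shown here, compound 2 gives the lowest number of the two; its only neighbour is compound 1, and the step of a 9.9-fold lower number from compound 1 to compound 2 (1.00 log units; beyond the scatter) separates them, a step beyond the scatter. Compound 3, `O=C(Nc1cccc(-c2oc3cc(-c4ccc(F)cc4)ccc3c(=O)c2O)c1)c1ccc(Cl)nc1`, is not yet measured. The change from compound 2 is 6-chloropyridin-3-yl in place of 3-fluorophenyl on a carbonyl carbon. Among the measured compounds shown here, only one measured step bears on this position, a 9.9-fold lower number from compound 1 to compound 2 (1.00 log units; beyond the scatter), which shows that swapping one ring on the carbonyl carbon for another moved the number well beyond the scatter. For the measured compounds named here, the direction it gives for compound 3 is not fixed: the entering ring carries a chlorine and a ring nitrogen, and neither has been tested, so the single step says only that the position matters. A number somewhat higher than that of compound 2 is expected, with a wide range either way. Compound 3 is therefore estimated at 5000 nM, between 1200 nM and 20000 nM, which is expected to correspond to the step of a 2.0-fold higher number from compound 2 to compound 3 (0.30 log units; within the scatter).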

Compound 3, half-maximal inhibitory concentration: 1760 nM
Compound 3: middle estimate off by 2.8-fold (0.45 log units), on the high side, and the stated range covers the measured number.
By their numbers in this assay, from the lowest: compounds 3 and 2 (each within the scatter of the next); then compound 1.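

In this assay, the step of a 1.4-fold lower number from compound 2 to compound 3 (0.15 log units; within the scatter) leaves 6-chloropyridin-3-yl and 3-fluorophenyl on the carbonyl carbon level with each other, so this position accepts a ring with a hetero atom as well as a ring of carbon only. Among these compounds, the step of a 14-fold lower number from compound 1 to compound 3 (1.15 log units; beyond the scatter) shows that the earlier gap was not particular to 3-fluorophenyl: two different rings now stand well clear of 4-bromophenyl, and compound 1 is the one compound that goes against their shared level. The hydrogen-bond acceptor counted on the entering ring brings no change beyond the scatter in this pair. No measured data on the compounds explain either step.

Chlorine and the ring nitrogen enter together, so this pair cannot show what each contributes alone; pyridin-3-yl without chlorine and 3-chlorophenyl would separate them. On these data alone, it also remains open whether 4-bromophenyl stands apart through bromine or through its ring position, which 4-fluorophenyl and 3-bromophenyl would address, and whether a ring is needed on the carbonyl carbon at all, which a saturated amine such as piperidine or a short alkyl chain would test.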